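Swapping the halogenated aryl group on a fused bicyclic core

The source may hold more compounds than are shown below. What is called first, only, known or untested is meant among the compounds shown, and "the series" means these compounds.

Of the compounds shown here, two of a shared core have been measured in a functional assay on Mahlavu cells (Homo sapiens) for inhibition, read by sulforhodamine B assay, with a stated time of 72 h; on this read-out lower numbers stand for stronger inhibition and higher numbers for weaker inhibition. Compound 1, `Cc1ccc(C2=Nn3c(nnc3C(C)c3ccc(CC(C)C)cc3)SC2)cc1`, gives 8500 nM in this assay. Compound 2, `CC(c1ccc(-c2ccccc2)c(F)c1)c1nnc2n1N=C(c1ccc(Cl)cc1Cl)CS2`, gives 6600 nM in this assay. Compound 2 has the lowest of the two numbers, but its nearest neighbour is compound 1, whose number is only slightly higher and sits within the scatter, so the two values cannot be told apart.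

Compound 3, `CC(c1ccc(-c2ccccc2)c(F)c1)c1nnc2n1N=C(c1ccc(Br)cc1)CS2`, has not yet been measured. It differs from compound 2 in one place: 4-bromophenyl in place of 2,4-dichlorophenyl on a carbon with a double bond to nitrogen. Within the data shown here, no measured pair in this set differs in only this one place, so the data give no direct precedent for the size or direction of such a change. Both measured compounds sit close together in this assay, and nothing among them points to a gain or a loss from this replacement.

The step of a 1.1-fold higher number from compound 2 to compound 3 (0.03 log units; within the scatter) is therefore expected to fall within the usual scatter. Compound 3 is estimated at 7000 nM in this assay, with a range from 2500 nM to 20000 nM.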

Compound 3, half-maximal inhibitory concentration: 6200 nM
For compound 3 the middle estimate is 1.1-fold (0.05 log units) above the measured one, and the stated range covers the measured number.
By their numbers in this assay, from the lowest: compounds 3, 2 and 1 (each within the scatter of the next).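

In this assay, among these compounds, replacing 2,4-dichlorophenyl with 4-bromophenyl on a carbon with a double bond to nitrogen gives a 1.1-fold lower number from compound 2 to compound 3 (0.03 log units; within the scatter), and this pair is the first in the set to isolate a change at this one place. The change swaps an aryl group of 8 heavy atoms with two chlorine atoms for one of 7 heavy atoms with a single bromine atom, and the two values cannot be told apart, so this place tolerates this particular exchange without a readable effect on the number. Nothing available here offers an explanation for that outcome.

The exchange alters the halogen pattern in more than one respect at once, so the compounds shown leave open what the loss of the chlorine at the 2 position and the exchange at the 4 position would each do alone. They also leave open whether this place stays as tolerant with an aryl group bearing something other than halogen, such as an amine or a carboxylic acid, or with a pyridine ring in place of the phenyl ring.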